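Carbamate replaces amide chain on the pyridone oxygen

A few compounds are considered here, and "the series" means these few. Any claim that something is new, unique, unknown or untested is made for them only; others in the source may bear on it.

Measured compounds:
compound 1 `CC(C)=CCC/C(C)=C/CC1Cc2c(OCc3ccccc3)cc(=O)n(CCCO)c2CC1(C)C` gives 1.5%
compound 2 `CC(C)=CCC/C(C)=C/CC1Cc2c(OCCCNC(=O)c3cccs3)cc(=O)n(CCCO)c2CC1(C)C` gives 11.5%

For the measured compounds named here, compound 2 stands highest of the two numbers in a functional assay on PANC-1 cells (Homo sapiens) for inhibition, read by MTT assay, with a stated time of 24 h, tested at 10 uM (a higher number here means more inhibition at the concentration tested (going by the name of the read-out), a lower number less inhibition), but its only neighbour, compound 1, sits within the usual scatter, as the step of a number 10 percentage points higher from compound 1 to compound 2 (within the scatter) shows. Compound 3 `COc1cccc(NC(=O)Oc2cc(=O)n(CCCO)c3c2CC(C/C=C(\C)CCC=C(C)C)C(C)(C)C3)c1` has not been measured. It differs from compound 2 by (3-methoxyphenyl)carbamoyl in place of 3-(((thiophen-2-yl)carbonyl)amino)propyl on an oxygen on an aromatic ring. Going by the values given here, the single measured step, from compound 1 to compound 2, changed the group on the same oxygen on the aromatic ring and stayed within the scatter; it is the only step that bears on the present change, and nothing beyond it is known about a carbamoyl group at this place. On that basis no step beyond the scatter is expected. Compound 3 is therefore estimated at 10%, with a range from 0% to 30%. The expected step is a number 1.5 percentage points lower from compound 2 to compound 3 (within the scatter).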

Compound 3, a percentage reported as inhibition, at one concentration (the size of the read-out at that concentration, not a potency): 11.3%
For compound 3 the middle estimate is 1.3 percentage points below the measured one; the range from low to high includes it.
By their numbers in this assay, from the lowest: compounds 1, 3 and 2 (each within the scatter of the next).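

Exchanging 3-(((thiophen-2-yl)carbonyl)amino)propyl for (3-methoxyphenyl)carbamoyl on an oxygen on an aromatic ring gives a number 0.2 percentage points lower from compound 2 to compound 3 (within the scatter) in this assay, and exchanging benzyl for the same group gives a number 9.8 percentage points higher from compound 1 to compound 3 (within the scatter). The position therefore now carries a carbamoyl group as well as two carbon-linked groups, and neither step to the carbamoyl compound leaves the scatter, so this change separates compound 3 from neither neighbour. No measurement here offers an explanation for these readings.

The compounds shown leave open whether an amine or a carboxylic acid on this oxygen would give a step beyond the scatter. They also leave open what a longer chain between the oxygen and the aromatic ring would do.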